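A few compounds are considered here, and "the series" means these few. Any claim that something is new, unique, unknown or untested is made for them only; others in the source may bear on it.

Of the compounds shown here, three built on one shared core have been measured in an assay on isolated protein (artery, Oryctolagus cuniculus) with Substance-P receptor (Homo sapiens) as the target; a higher number here means weaker binding, a lower number tighter binding. Compound 1 `O=C1CCC(CCN2CC(N3CCNCC3)C2)(c2ccc(Cl)c(Cl)c2)CN1Cc1ccccc1` gives 5.01 nM. Compound 2 `CS(=O)(=O)N1CCN(C2CN(CCC3(c4ccc(Cl)c(Cl)c4)CCC(=O)N(Cc4ccccc4)C3)C2)CC1` gives 0.631 nM, and the step of a 7.9-fold lower number from compound 1 to compound 2 (0.90 log units; beyond the scatter) comes from a methylsulfonyl in place of hydrogen on the piperazine nitrogen. Compound 3 `O=C1CCC(CCN2CC(N3CCNCC3)C2)(c2ccc(Cl)c(Cl)c2)CN1CC1CC1` gives 12.6 nM, the highest of the three numbers in this assay; it lies furthest from compound 2 and nearest to compound 1, and the step of a 2.5-fold higher number from compound 1 to compound 3 (0.40 log units; beyond the scatter) is the only one that separates it from compound 1.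

Compound 4 `CS(=O)(=O)N1CCN(C2CN(CCC3(c4ccc(Cl)c(Cl)c4)CCC(=O)N(CC4CC4)C3)C2)CC1` has not yet been measured in this assay. It differs from compound 3 by methylsulfonyl in place of hydrogen on an amine nitrogen in a ring, the same change that turns compound 1 into compound 2. That single measured precedent is modest but beyond the scatter, and there is nothing here to suggest the cyclopropyl-bearing core should respond differently. Compound 4 is therefore expected to show a step of a 7.9-fold lower number from compound 3 to compound 4 (0.90 log units; beyond the scatter) in this assay, a lower number than compound 3 because the matching change gave a 7.9-fold lower number from compound 1 to compound 2 (0.90 log units; beyond the scatter). Compound 4 is thus estimated at 1.6 nM, within a range from 0.6 nM to 4.5 nM.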

Compound 4, dissociation constant: 3.16 nM
Beside the measured number, compound 4's estimate is 2.0-fold (0.30 log units) below it, and the stated range covers the measured number.
By their numbers in this assay, from the lowest: compound 2; then compounds 4 and 1 (each within the scatter of the next); then compound 3.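

In this assay, methylsulfonyl in place of hydrogen on the piperazine amine nitrogen again lowers the number, now on the cyclopropyl-bearing core, with a 4.0-fold lower number from compound 3 to compound 4 (0.60 log units; beyond the scatter), so the direction of this change holds on a second core and its size agrees with the earlier step: the same change on two cores in this assay, a 7.9-fold lower number (0.90 log units; beyond the scatter) from compound 1 to compound 2 and a 4.0-fold lower number (0.60 log units; beyond the scatter) from compound 3 to compound 4, 2.0-fold (0.30 log units) apart, within the scatter of two such steps
The reverse pairing shows for the first time that cyclopropyl in place of phenyl also raises the number when methylsulfonyl is present, with a 5.0-fold higher number from compound 2 to compound 4 (0.70 log units; beyond the scatter), and this step agrees in size with the one seen without methylsulfonyl: the same change on two cores in this assay, a 2.5-fold higher number (0.40 log units; beyond the scatter) from compound 1 to compound 3 and a 5.0-fold higher number (0.70 log units; beyond the scatter) from compound 2 to compound 4, 2.0-fold (0.30 log units) apart, within the scatter of two such steps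
Across these four compounds, then, neither change shifts the step of the other by more than the scatter of two such steps.

From the compounds shown here alone, it remains open whether an acetyl group or a plain methyl on that same amine nitrogen would lower the number as methylsulfonyl does. Going by these compounds, it is also open how a longer alkyl chain in place of the cyclopropyl would fare on either form of the piperazine.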